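Replacing 4-butoxyphenyl with 2-fluorophenyl: notes on compound 3

The compounds below may be only part of what the source reports. "The series", "measured", "known", "first", "only" and "open" are said of these compounds alone.

Values so far in a functional assay on SGC-7901 cells (Homo sapiens) for antiproliferative activity, read by MTT assay, with a stated time of 24 h (on this read-out higher numbers stand for weaker inhibition and lower numbers for stronger inhibition), for the two measured compounds
- compound 1 `O=C(NNc1ccccc1F)c1ccccc1NS(=O)(=O)c1cnc(O)nc1O` gives > 20000 nM as a limit of the assay and not a number
- compound 2 `CCCCOc1ccc(C(=O)NNC(=O)c2ccc(NS(=O)(=O)c3cnc(O)nc3O)cc2)cc1` gives 14700 nM as a measured number

Going by the values given here, compound 2 at 14700 nM holds the only actual number so far in this assay and has no measured step linking it to another compound. Compound 3 `O=C(NNC(=O)c1ccccc1F)c1ccc(NS(=O)(=O)c2cnc(O)nc2O)cc1` differs from compound 2 by one change 2-fluorophenyl in place of 4-butoxyphenyl on a carbonyl carbon with 2-fluorophenyl in place of 4-butoxyphenyl on a carbonyl carbon. Among the compounds with values here, no measured step covers this change, so the expectation rests on compound 2 at 14700 nM alone. In this assay no shift beyond the usual scatter is expected, and neither direction is favoured. The estimated step is a 1.0-fold higher number from compound 2 to compound 3 (0.01 log units; within the scatter) and it remains uncertain. For compound 3 the estimated value is 15000 nM with an expected range of 6000 nM to 25000 nM. A limit of the assay in place of a number remains possible for compound 3.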

Compound 3, half-maximal inhibitory concentration: > 20000 nM
Compound 3 gave a limit, no number; the forecaster's own chance of this, stated with the estimate: 40%; at least 1.3-fold (0.12 log units) between middle value and limit.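

In this assay, going by these compounds alone, 2-fluorophenyl in place of 4-butoxyphenyl on a carbonyl carbon gives an at least 1.3-fold higher number from compound 2 to compound 3 (0.13 log units; that floor lies within the scatter), the only step that can be read so far. Compound 3 gives > 20000 nM, which is a limit of the assay and not a number. The 2-fluorophenyl group therefore does not return a measured value at this position, and the true size of the step stays unknown because the read-out ends at this limit: the limit of > 20000 nM in this assay, at which 2 of the 3 values shown sit.

Two groups at one position cannot show whether the butoxy chain, the ring or the fluorine governs the result. Going by these compounds, it remains open whether a hexyloxy chain or an amine on the phenyl ring would move the value away from compound 2 at 14700 nM.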